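Three Compounds at the Limit, One Still to Measure

The source may report more compounds than this note shows. Statements on the series, on what has been measured and on what is new or still open speak of the compounds shown alone.

Compound 1, `CCN(CC)S(=O)(=O)c1ccc(S(=O)(=O)N2CCC[C@@H](C(=O)NC3CN(C(=O)OC(C)(C)C)C3)C2)cc1`, in a functional assay on MIA PaCa-2 cells (Homo sapiens) for inhibition, read by MTT assay, with a stated time of 3 days (on this read-out lower numbers stand for stronger inhibition and higher numbers for weaker inhibition), gives a limit of > 10000 nM.
Compound 2, `CCOC(=O)[C@@H]1CCCN(S(=O)(=O)c2ccc(S(=O)(=O)N(CC)CC)nc2)C1`, in this assay gives a limit of > 10000 nM.
Compound 3, `CCOC(=O)[C@H]1CCN(S(=O)(=O)c2ccc(S(=O)(=O)N(CC)CC)cc2)C1`, in this assay gives a limit of > 10000 nM.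

Compound 1 therefore stands nowhere above its companions: every value here is a limit rather than a number, as the limit of > 10000 nM in this assay, at which 3 of the 3 values shown sit, records, and none of the three can be ordered against another. The untested compound 4, `CCN(CC)C(=O)[C@@H]1CCCN(S(=O)(=O)c2ccc(S(=O)(=O)N(CC)CC)cc2)C1`, differs from compound 1 in one place: diethylamino in place of (1-(tert-butoxycarbonyl)azetidin-3-yl)amino on a carbonyl carbon. Among the compounds with values here, with no measured step available between any pair, the expectation in this assay is for no change beyond the scatter, and the step that the limit leaves unreadable from compound 1 to compound 4 is estimated accordingly to leave compound 4 at the limit. Compound 4 is expected to give about 20000 nM, somewhere between 5000 nM and 80000 nM.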

Compound 4, half-maximal inhibitory concentration: > 10000 nM
Compound 4 was reported as a limit (the forecaster's own chance of this, stated with the estimate: 85%); the middle value is on the limit's open side.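

In this assay compound 4 gives > 10000 nM, which is a limit. Compound 1 is also reported only as a limit, so no step can be read between compound 1 and compound 4. The compounds shown leave open how any of them ranks against another, as all rest at one reading: the limit of > 10000 nM in this assay, at which 4 of the 4 values shown sit.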